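The source may report more compounds than this note shows. Statements on the series, on what has been measured and on what is new or still open speak of the compounds shown alone.

Three ureas built on one shared core were tested in a functional assay on HCC827 cells (Homo sapiens) for inhibition, read by MTT assay, with a stated time of 48 h, tested at 10 uM; on this read-out higher numbers stand for more inhibition at the one concentration tested (going by the name of the read-out) and lower numbers for less inhibition. Compound 1 `COc1cc(NC(=O)Nc2cc(Nc3ccc(F)c(Cl)c3)ncn2)cc(OC)c1` gives 53.1%, compound 2 `CCc1cccc(Nc2cc(NC(=O)Nc3cc(OC)cc(OC)c3)ncn2)c1` gives 52.6%, and compound 3 `COc1cc(NC(=O)Nc2cc(Nc3ccc(Br)cc3OC)ncn2)cc(OC)c1` gives 57.7%. Compound 3 sits with the other two: the step of a number 4.6 percentage points higher from compound 1 to compound 3 (within the scatter) and the step of a number 5.1 percentage points higher from compound 2 to compound 3 (within the scatter) are both within the scatter, as is a number 0.5 percentage points lower from compound 1 to compound 2 (within the scatter).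

Compound 4 `COc1cc(NC(=O)Nc2cc(Nc3ccc(OC)c(I)c3)ncn2)cc(OC)c1` is not yet measured. It differs from compound 3 in one place: 3-iodo-4-methoxyphenyl in place of 4-bromo-2-methoxyphenyl on a nitrogen on an aromatic ring. Every measured step here swaps the aryl group on that same nitrogen, and none of them moved the read-out beyond the scatter. The expected step of a number 2.7 percentage points lower from compound 3 to compound 4 (within the scatter) is therefore no change beyond the scatter, and in this assay compound 4 is expected to give about 55%, in a range from 44% to 66%.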

Compound 4, a percentage reported as inhibition, at one concentration (the size of the read-out at that concentration, not a potency): 61.7%
Estimate against measurement, compound 4: 6.7 percentage points below, and the stated range covers the measured number.
By their numbers in this assay, from the lowest: compounds 2, 1, 3 and 4 (each within the scatter of the next).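

In this assay the swap to 3-iodo-4-methoxyphenyl gives a number 4 percentage points higher from compound 3 to compound 4 (within the scatter) and so adds a fourth aryl group on this nitrogen with no change beyond the scatter. The two wider comparisons, a number 9.1 percentage points higher from compound 2 to compound 4 (within the scatter) and a number 8.6 percentage points higher from compound 1 to compound 4 (within the scatter), show the same, so the iodine and the different methoxy placement together leave the read-out within the scatter of all three earlier groups. Nothing available here explains this result. The compounds shown leave open what an aryl group carrying an amine or a carboxylic acid would do on this nitrogen. They also cannot separate the swap of bromine for iodine from the shift of the methoxy group.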